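Working notes: the step from compound 3 to compound 4

The source may report more compounds than this note shows. Statements on the series, on what has been measured and on what is new or still open speak of the compounds shown alone.

In a functional assay on HeLa cells (Homo sapiens) for inhibition, read by MTT assay, with a stated time of 48 h (a lower number here means a stronger inhibitor, a higher number a weaker inhibitor), compound 3 (`CCOC(=O)C1=C(N/N=C(/Cl)c2ccc([N+](=O)[O-])cc2)Nc2[nH]nc(C)c2C1c1ccc(N(C)C)cc1`) reads (46200 nM) and sits level with compound 1 (`CCOC(=O)C1=C(N/N=C(\C#N)C(N)=O)Nc2[nH]nc(C)c2C1c1ccc(N(C)C)cc1`), which reads (47300 nM). Both stand at the high end of the numbers. On the same scale, compound 2 (`CCOC(=O)C1=C(N/C=N/c2ncc(-c3ccccc3)s2)Nc2[nH]nc(C)c2C1c1ccc(N(C)C)cc1`) reads (15400 nM). The gap between compound 3 and compound 2 lies beyond the scatter. Compound 4 (`CCOC(=O)C1=C(N/N=C(/C(=O)Br)c2ccc(Cl)cc2)Nc2[nH]nc(C)c2C1c1ccc(N(C)C)cc1`) carries a group of 12 heavy atoms (8 carbon, 1 nitrogen, 1 oxygen, 1 chlorine, 1 bromine; one six-membered aromatic ring of carbon only) in place of a group of 12 heavy atoms (7 carbon, 2 nitrogen, 2 oxygen, 1 chlorine; one six-membered aromatic ring of carbon only), on an amine nitrogen as its change. Among the measured compounds shown here, the one measured step at this amine nitrogen is a 1.0-fold lower number from compound 1 to compound 3 (0.01 log units; within the scatter) and stays within the scatter, so no step beyond the scatter is expected in this assay. The expected step is small (a 1.1-fold lower number from compound 3 to compound 4 (0.04 log units; within the scatter)). Compound 2 keeps the range wide. For compound 4 the estimated value is 42000 nM within an expected range of 18000 nM to 95000 nM as its span.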

Compound 4, half-maximal inhibitory concentration: 49300 nM
Compound 4: the middle estimate sits 1.2-fold (0.07 log units) below what was measured; the measured number falls inside the stated range.
By their numbers in this assay, from the lowest: compound 2; then compounds 3, 1 and 4 (each within the scatter of the next).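

In this assay, replacing one ring-bearing group on the amine nitrogen with another, with bromine entering, gives a 1.1-fold higher number from compound 3 to compound 4 (0.03 log units; within the scatter). The wider replacement gives a 1.0-fold higher number from compound 1 to compound 4 (0.02 log units; within the scatter), so three different groups at this place now read level, and the earlier single step no longer stands alone. No supporting measurement bears on this result. Going by these compounds, whether an amine or a carboxylic acid in this group would move the number stays open. Also open, on these data alone, is whether this level reading holds in any other assay.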